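Ethoxycarbonyl in place of methyl: will tolerance hold?

This account rests on a few compounds, and the source may have more. Where it says the series, first, only, none or still open, it means among the compounds named here.

Compound 1 (`CNNC(=O)c1[nH]c2ccc(Cl)cc2c1S(=O)(=O)c1cc(C)cc(C)c1`) is the starting point, measured in a functional assay on cells (Lymphocyte, Homo sapiens) for cytotoxicity; a lower number here means that less compound is tolerated, a higher number that more compound is tolerated. Compound 1 gives > 100 uM, which is a limit of the assay and not a number. Compound 2 (`Cc1cc(C)cc(S(=O)(=O)c2c(C(=O)NNC3CCCCC3)[nH]c3ccc(Cl)cc23)c1`) has cyclohexyl in place of methyl on an amine nitrogen. Compound 2 gives > 100 uM, which is also a limit. Within the data shown here, the only measured step, a step that the two limits leave unreadable from compound 1 to compound 2, therefore has no size to carry forward. What the data do offer is the limit of > 100 uM in this assay, at which 2 of the 2 values shown sit.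

Compound 3 (`CCOC(=O)NNC(=O)c1[nH]c2ccc(Cl)cc2c1S(=O)(=O)c1cc(C)cc(C)c1`) is changed on that same amine nitrogen, with ethoxycarbonyl in place of methyl on an amine nitrogen. Its new group differs from cyclohexyl, so compound 2 is only a loose guide. Still, neither measured compound has yet given a number in this assay, and nothing in the data points towards a drop or a rise. The expected step is a number no higher from compound 1 to compound 3 (the limit leaves the size open), which means no change beyond the usual scatter is expected in this assay. For compound 3 the estimated value is 100 uM, with an expected range of 35 uM to 200 uM.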

Compound 3, half-maximal toxic concentration: > 100 uM
Compound 3: no number, only a limit (the forecaster's own chance of this, stated with the estimate: 70%); the middle value sits exactly at the limit.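

Compound 3, like compound 1 and compound 2, gives a limit and not a number, so the steps among these three compounds cannot be read: the limit of > 100 uM in this assay, at which 3 of the 3 values shown sit.

The compounds shown leave open what actual number any of them would give in this assay, and whether methyl, cyclohexyl or ethoxycarbonyl on that amine nitrogen makes any difference there.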